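The source may hold more compounds than are shown below. What is called first, only, known or untested is meant among the compounds shown, and "the series" means these compounds.

Working notes on the series. For the measured compounds named here, in an assay on HEK293 cells for activation of Kir3.1/Kir3.2 (Homo sapiens), read by thallium flux (on this read-out higher numbers stand for an effect only at larger amounts of compound and lower numbers for an effect already at smaller amounts), compound 3 `Cc1cc(NC(=O)Cn2nnc(-c3ccc(C(F)(F)F)cc3)n2)n(C2CCCCC2)n1` gives 241 nM, the highest of the three numbers so far; compound 1 `Cc1cc(NC(=O)Cn2nnc(-c3ccccc3)n2)n(C2CCCCC2)n1` gives 96 nM and compound 2 `Cc1cc(NC(=O)Cn2nnc(-c3cccc(F)c3)n2)n(C2CCCCC2)n1` gives 81 nM. Two steps separate compound 3 from the others: a 2.5-fold higher number from compound 1 to compound 3 (0.40 log units; beyond the scatter) and a 3.0-fold higher number from compound 2 to compound 3 (0.47 log units; beyond the scatter), both beyond the scatter, whereas a 1.2-fold lower number from compound 1 to compound 2 (0.07 log units; within the scatter) is within it. Compound 4 `Cc1cc(NC(=O)Cn2nnc(-c3cccc(C#N)c3)n2)n(C2CCCCC2)n1` differs from compound 3 by 3-cyanophenyl in place of 4-(trifluoromethyl)phenyl on an aromatic carbon. Going by the values given here, no measured compound carries a 3-cyanophenyl, so the only bearing steps are those that brought the 4-(trifluoromethyl)phenyl in; removing it should undo most of that rise. Compound 4 is therefore expected to give about 100 nM in this assay, with a range from 50 nM to 220 nM, meaning an expected step of a 2.4-fold lower number from compound 3 to compound 4 (0.38 log units; beyond the scatter).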

Compound 4, half-maximal effective concentration: 183 nM
Beside the measured number, compound 4's estimate is 1.8-fold (0.26 log units) below it, and the stated range covers the measured number.
By their numbers in this assay, from the lowest: compounds 2, 1, 4 and 3 (each within the scatter of the next, the first and the last beyond it).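

The 3-cyanophenyl in place of 4-(trifluoromethyl)phenyl gives a 1.3-fold lower number from compound 3 to compound 4 (0.12 log units; within the scatter), so this exchange does not bring the number back as a removal of the 4-(trifluoromethyl)phenyl might have. Cyano in place of fluoro gives a 2.3-fold higher number from compound 2 to compound 4 (0.35 log units; beyond the scatter), whereas cyano in place of hydrogen gives a 1.9-fold higher number from compound 1 to compound 4 (0.28 log units; within the scatter), so at this position only the comparison with fluoro separates the nitrile. Nothing available on these compounds accounts for this result. The exchange alters both the group and its place on the phenyl, and these two effects remain unseparated. On these data alone, how an amine or a carboxylic acid on that phenyl would read remains open.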